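The compounds below may be only part of what the source reports. "The series", "measured", "known", "first", "only" and "open" are said of these compounds alone.

Working notes on the series. All four compounds share the core of compound 1, `CCCCCCCC(=O)NCC(C)(C)CC1=C(O)C(=O)c2ccccc2C1=O`, and differ only in the acyl chain on the amide. In a functional assay on KB cells (Homo sapiens) for cytotoxicity, read by resazurin assay, with a stated time of 3 days (a lower number here means a stronger inhibitor, a higher number a weaker inhibitor), compound 1 gives 24600 nM. Compound 2, `CCCCCCC(C)C(=O)NCC(C)(C)CC1=C(O)C(=O)c2ccccc2C1=O`, carries methyl in place of hydrogen on a saturated chain carbon bound to a carbonyl carbon and a saturated chain carbon; the step of a 1.0-fold lower number from compound 1 to compound 2 (0.02 log units; within the scatter). Compound 3, `CCCCCCCCCC(=O)NCC(C)(C)CC1=C(O)C(=O)c2ccccc2C1=O`, differs from compound 1 by ethyl in place of hydrogen on a saturated chain carbon, seven bonds along the chain from a carbonyl carbon, and in this assay compound 3 gives 18500 nM. Within the data shown here, compound 2 in this assay gives 23700 nM; the steps of a 1.3-fold lower number from compound 1 to compound 3 (0.12 log units; within the scatter) and a 1.3-fold lower number from compound 2 to compound 3 (0.11 log units; within the scatter), so no compound stands apart.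

Compound 4, `CCCCCCCCCCC(=O)NCC(C)(C)CC1=C(O)C(=O)c2ccccc2C1=O`, is not yet measured. It differs from compound 3 by methyl in place of hydrogen on a saturated chain carbon, nine bonds along the chain from a carbonyl carbon. This is the same kind of change as from compound 1 to compound 2, but the place is not the same: there the methyl enters on a saturated chain carbon bound to a carbonyl carbon and a saturated chain carbon, here nine bonds along the chain from a carbonyl carbon. Given that each chain change so far stayed within the scatter, notably a 1.3-fold lower number from compound 1 to compound 3 (0.12 log units; within the scatter), the expected step is a 1.2-fold lower number from compound 3 to compound 4 (0.06 log units; within the scatter). Compound 4 is estimated at 16000 nM in this assay, between 8000 nM and 35000 nM.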

Compound 4, half-maximal inhibitory concentration: 17600 nM
The estimate for compound 4 lay 1.1-fold (0.04 log units) below the measured number, within the range that was stated.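

In this assay the same change on the two cores gives steps that do not differ: the same change on two cores in this assay, a 1.0-fold lower number (0.02 log units; within the scatter) from compound 1 to compound 2 and a 1.1-fold lower number (0.02 log units; within the scatter) from compound 3 to compound 4, 1.0-fold (0.01 log units) apart, within the scatter of two such steps. Read singly, a 1.1-fold lower number from compound 3 to compound 4 (0.02 log units; within the scatter) cannot be told from noise, and the same holds for a 1.3-fold lower number from compound 2 to compound 4 (0.13 log units; within the scatter) and for a 1.4-fold lower number from compound 1 to compound 4 (0.15 log units; within the scatter), so the four acyl chains shown do not separate. This shows that methyl in place of hydrogen left the number unmoved at both places in these compounds; it does not show that an effect carries from one core to another, as neither step holds a real effect to carry and the methyl enters at two different places, once on a saturated chain carbon bound to a carbonyl carbon and once nine bonds along the chain from a carbonyl carbon.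

Open, on these data alone, is whether a much longer chain, or a chain ending in an amine or a carboxylic acid, would give a step beyond the scatter. Also open, as far as these compounds go, is whether any change outside the acyl chain, on the shared core, would do so.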